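The source may hold more compounds than are shown below. What is called first, only, known or untested is meant among the compounds shown, and "the series" means these compounds.

In a functional assay on HeLa S3 cells (Homo sapiens) for antiproliferative activity, read by XTT assay, with a stated time of 72 h (a lower number here means a stronger inhibitor, a higher number a weaker inhibitor), compound 3 `Cc1ncnc2c1c(-c1cc3ccccc3o1)cn2[C@@H]1O[C@H](CO)[C@@H](O)[C@H]1O` gives only a limit, > 20000 nM. Compound 2 `Cc1ncnc2c1c(-c1cccs1)cn2[C@@H]1O[C@H](CO)[C@@H](O)[C@H]1O` also gives only a limit, > 15000 nM. Among the compounds with values here, the one measured step, a step that the two limits leave unreadable from compound 2 to compound 3, therefore has no readable size and offers little guidance. Compound 4 `C#Cc1cn([C@@H]2O[C@H](CO)[C@@H](O)[C@H]2O)c2ncnc(C)c12` has ethynyl in place of the 1-benzofuran-2-yl of compound 3: ethynyl in place of 1-benzofuran-2-yl on an aromatic carbon. Compound 1 `C#Cc1cn([C@@H]2O[C@H](CO)[C@@H](O)[C@H]2O)c2ncnc(OC)c12` also carries ethynyl and gives 1730 nM, so a large move toward stronger inhibition is expected in this assay, though this rests on compound 1 alone. The expected step is an at least 20-fold lower number from compound 3 to compound 4 (1.30 log units; beyond the scatter). Compound 4 is estimated at 1000 nM, with an expected range of 150 nM to 6000 nM.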

Compound 4, half-maximal inhibitory concentration: 14700 nM
For compound 4 the middle estimate is 15-fold (1.17 log units) below the measured one, outside the stated range (above it).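

Replacing a ring at this position with ethynyl gives only floors, an at least 1.3-fold lower number from compound 3 to compound 4 (0.13 log units; that floor lies within the scatter) and an at least 1.0-fold lower number from compound 2 to compound 4 (0.00 log units; that floor lies within the scatter), since compound 2 and compound 3 are known only as limits. Ethynyl at this position therefore brings no shown gain over either ring. With ethynyl held fixed, the group elsewhere on the core does matter in this assay: an 8.5-fold higher number from compound 1 to compound 4 (0.93 log units; beyond the scatter).

On these data alone, how far compound 4 truly lies from compound 2 and compound 3 stays open. So does whether an amine in place of the methoxy or methyl would give a lower number than methoxy does.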